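This account rests on a few compounds, and the source may have more. Where it says the series, first, only, none or still open, it means among the compounds named here.

In a functional assay on U-373MG ATCC cells (Homo sapiens) for inhibition, read by MTT assay, with a stated time of 72 h (a lower number here means a stronger inhibitor, a higher number a weaker inhibitor), compound 1 (`CC1(C)CC(NC(=S)Nc2cccc(C#N)c2)c2cc(Br)ccc2O1`) gives 6000 nM. Among the compounds with values here, the only other number on this scale comes from compound 2 (`CC1(C)CC(NC(=S)Nc2cccc([N+](=O)[O-])c2)c2cc(Br)ccc2O1`), which gives 4000 nM, and the two values lie within the scatter of each other. Compound 3 (`COc1ccccc1NC(=S)NC1CC(C)(C)Oc2ccc(Br)cc21`) has not yet been measured. It differs from compound 1 at a single place: 2-methoxyphenyl in place of 3-cyanophenyl on an amide-type nitrogen. In words, 2-methoxyphenyl stands in place of 3-cyanophenyl on an amide-type nitrogen, while the core of compound 1 is kept. Within the data shown here, only one measured step bears on this change, and only indirectly: a 1.5-fold lower number from compound 1 to compound 2 (0.18 log units; within the scatter). Among the measured compounds shown here, that exchange of nitro for cyano on an aromatic carbon stays within the scatter, but it does not test a 2-methoxyphenyl group, and no measured compound carries one. The data therefore point in no clear direction, and no step beyond the scatter is expected in this assay. The estimated change is a 1.2-fold lower number from compound 1 to compound 3 (0.08 log units; within the scatter). Compound 3 is expected to give 5000 nM. Its estimated range runs from 2000 nM to 12000 nM.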

Compound 3, half-maximal inhibitory concentration: 22000 nM
The estimate for compound 3 lay 4.4-fold (0.64 log units) below the measured number; the measured number lies above the stated range.
By their numbers in this assay, from the lowest: compounds 2 and 1 (each within the scatter of the next); then compound 3.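

In this assay, the group on the amide-type nitrogen now gives a step beyond the scatter, a 3.7-fold higher number from compound 1 to compound 3 (0.56 log units; beyond the scatter), whereas the earlier exchange, a 1.5-fold lower number from compound 1 to compound 2 (0.18 log units; within the scatter), stayed within it. This modest step shows that the position does not treat all aryl groups alike: with the core of compound 1 kept, 2-methoxyphenyl gives a weaker inhibitor than 3-cyanophenyl, although both groups have the same count of heavy atoms and one six-membered aromatic ring of carbon only. No measurement offered here accounts for the difference between these two groups.

The compounds shown do not tell whether the step belongs to the methoxy group itself or to where it stands in 2-methoxyphenyl. They also leave open how an aryl group carrying an amine or a carboxylic acid would read on this scale, and whether a longer chain on the same amide-type nitrogen would keep the number near that of compound 1 or raise it further.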